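Chloro to Trifluoromethyl on the Benzyl Ring

This account rests on a few compounds, and the source may have more. Where it says the series, first, only, none or still open, it means among the compounds named here.

Measured compounds:
Compound 1, `Cc1cc(S(=O)(=O)/N=C(\N)n2nccc2-c2ccccc2)c(SCc2cccc3ccccc23)cc1Cl`, in a functional assay on HCT-116 cells (Homo sapiens) for cytotoxicity, read by MTT assay, with a stated time of 72 h (on this read-out higher numbers stand for weaker inhibition and lower numbers for stronger inhibition), gives 7000 nM.
Compound 2, `Cc1cc(S(=O)(=O)/N=C(\N)n2nccc2-c2ccccc2)c(SCc2ccccc2Cl)cc1Cl`, in this assay gives 18000 nM.

Compound 2 holds the highest of the two numbers in this assay. Its nearest neighbour is compound 1, and the step between them is a 2.6-fold higher number from compound 1 to compound 2 (0.41 log units; beyond the scatter), which came with 2-chlorophenyl replacing naphthalen-1-yl on the saturated chain carbon bound to sulfur.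

Compound 3, `Cc1cc(S(=O)(=O)/N=C(\N)n2nccc2-c2ccccc2)c(SCc2ccccc2C(F)(F)F)cc1Cl`, differs from compound 2 in a single place: trifluoromethyl in place of chloro on an aromatic carbon. Going by the values given here, the only measured step concerns the exchange of the whole aryl group on the benzylic carbon, not a substituent on that ring, so it does not bear directly on this change. In the absence of any step that speaks to it, the expectation for this assay is a step no larger than the usual scatter, in no fixed direction, which is what no change at the digits printed from compound 2 to compound 3 (within the scatter) expresses. Compound 3 is therefore estimated at 18000 nM, with a range from 8000 nM to 45000 nM.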

Compound 3, half-maximal inhibitory concentration: 16000 nM
Compound 3: the middle estimate sits 1.1-fold (0.05 log units) above what was measured, within the range that was stated.
By their numbers in this assay, from the lowest: compound 1; then compounds 3 and 2 (each within the scatter of the next).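

In this assay, trifluoromethyl in place of chloro on an aromatic carbon, ortho to a large group, gives a 1.1-fold lower number from compound 2 to compound 3 (0.05 log units; within the scatter), so this read-out does not tell the two groups apart at this position, although the group that enters is the larger by heavy-atom count. The exchange of the whole aryl group now has a second example: 2-(trifluoromethyl)phenyl in place of naphthalen-1-yl gives a 2.3-fold higher number from compound 1 to compound 3 (0.36 log units; beyond the scatter), of similar kind to a 2.6-fold higher number from compound 1 to compound 2 (0.41 log units; beyond the scatter), so among these three compounds both substituted phenyl groups give higher numbers than naphthalen-1-yl, and none of them goes against this. Nothing among the data shown accounts for the two groups reading alike or for the gap to naphthalen-1-yl.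

Going by these compounds, it remains open whether a quite different group at this place on the ring, such as an amine, a methoxy group or a carboxylic acid, would also read alike, or whether plain hydrogen there would shift the number. On these data alone, it is equally open whether the two groups would still read alike on another aromatic carbon of the ring, or with a longer chain between the sulfur and the ring.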